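Anilide variation on a cyclopropane-linked aminopyrimidine series

The source may hold more compounds than are shown below. What is called first, only, known or untested is meant among the compounds shown, and "the series" means these compounds.

Measured compounds in a functional assay on T47D cells (Homo sapiens) for inhibition, read by CCK-8 assay, with a stated time of 72 h, tested at 1 uM; on this read-out lower numbers stand for less inhibition of growth and higher numbers for more inhibition of growth at the one concentration tested:
- compound 1, `CN(C)C(=O)c1cc2cnc(Nc3ccc(NC(=O)C4(C(=O)Nc5ccc(Br)cc5)CC4)cc3)nc2n1C1CCCC1`, 21.1%
- compound 2, `CN(C)C(=O)c1cc2cnc(Nc3ccc(NC(=O)C4(C(=O)Nc5ccc(O)cc5)CC4)cc3)nc2n1C1CCCC1`, 91.5%
- compound 3, `Cc1cccc(NC(=O)C2(C(=O)Nc3ccc(Nc4ncc5cc(C(=O)N(C)C)n(C6CCCC6)c5n4)cc3)CC2)c1`, 45.7%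

The three compounds share one core and differ only in the aryl group on the outer amide-type nitrogen. Compound 3 stands second highest of the three numbers in this assay: a number 24.6 percentage points higher from compound 1 to compound 3 (beyond the scatter), while a number 45.8 percentage points lower from compound 2 to compound 3 (beyond the scatter). The largest step is a number 70.4 percentage points higher from compound 1 to compound 2 (beyond the scatter), so the substituent on this ring moves the read-out strongly.

Compound 4, `COc1ccc(NC(=O)C2(C(=O)Nc3ccc(Nc4ncc5cc(C(=O)N(C)C)n(C6CCCC6)c5n4)cc3)CC2)cc1`, is not yet measured. It differs from compound 3 in one place: 4-methoxyphenyl in place of 3-methylphenyl on an amide-type nitrogen. Among the measured compounds shown here, the steps that bear on this change are those in which 3-methylphenyl entered, namely the modest rise from compound 1 and the large fall from compound 2. A 4-methoxyphenyl group carries a ring oxygen like the 4-hydroxyphenyl of compound 2 but without its donor, so the step is expected to lie between those two outcomes. For compound 4 a moderate rise relative to compound 3 is expected, a number 12.3 percentage points higher from compound 3 to compound 4 (beyond the scatter). The estimate for compound 4 in this assay is 58%, within a range from 32% to 82%.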

Compound 4, percent growth inhibition at one concentration: 76.4%
For compound 4 the middle estimate is 18.4 percentage points below the measured one, within the range that was stated.
By their numbers in this assay, from the lowest: compound 1; then compound 3; then compound 4; then compound 2.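

In this assay a free hydroxy is not needed for most of the inhibition of growth, since methyl in place of hydrogen on that oxygen gives a number 15.1 percentage points lower from compound 2 to compound 4 (beyond the scatter) and compound 4 keeps a high number without the hydrogen-bond donor of compound 2. The oxygen-bearing ring also stands clear of both compounds without oxygen: methoxy in place of bromo gives a number 55.3 percentage points higher from compound 1 to compound 4 (beyond the scatter) and 4-methoxyphenyl in place of 3-methylphenyl gives a number 30.7 percentage points higher from compound 3 to compound 4 (beyond the scatter) in the same assay. Among these four compounds, both with an oxygen on this ring therefore rank above both without one, and no compound shown goes against that order.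

No measurement shown explains this order. The step from compound 3 to compound 4 changes both the group and its place on the ring, so 4-methylphenyl and 3-methoxyphenyl would be needed to separate those two changes, while an amine or a carboxylic acid on the ring, or ethoxy as a longer chain on the oxygen, would test how far the oxygen trend extends.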